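From azetidine amide to methyl amide

This account rests on a few compounds, and the source may have more. Where it says the series, first, only, none or still open, it means among the compounds named here.

In a functional assay on BT-474 cells (Homo sapiens) for antiproliferative activity, read by sulforhodamine B assay, with a stated time of 4 days (on this read-out lower numbers stand for stronger inhibition of growth and higher numbers for weaker inhibition of growth), compound 3 (`COc1cc(Cl)c(-c2nc(SCC(=O)N3CCC3)nc3[nH]cc(C#N)c23)cc1OC`) gives 31 nM as the lowest of three numbers on this read-out. Compound 1 (`COc1cc(Cl)c(-c2nc(SCC(=O)NC3CC3)nc3[nH]cc(C#N)c23)cc1OC`) gives 69 nM and compound 2 (`COc1cc(Cl)c(-c2nc(SCC(=O)NC(C)(C)C)nc3[nH]cc(C#N)c23)cc1OC`) gives 121 nM. The gaps from both of them to compound 3 lie beyond the scatter. Compound 4 (`CNC(=O)CSc1nc(-c2cc(OC)c(OC)cc2Cl)c2c(C#N)c[nH]c2n1`) has methylamino in place of azetidin-1-yl on a carbonyl carbon. Among the compounds with values here, two measured steps bear on this in reverse: azetidin-1-yl replacing cyclopropylamino gave a 2.2-fold lower number from compound 1 to compound 3 (0.35 log units; beyond the scatter) and, replacing (tert-butyl)amino, gave a 3.9-fold lower number from compound 2 to compound 3 (0.59 log units; beyond the scatter) as the larger one. The step between those amino groups was a 1.8-fold higher number from compound 1 to compound 2 (0.24 log units; within the scatter) and adds little. In this assay a modest rise is therefore expected, with the estimated step of a 2.3-fold higher number from compound 3 to compound 4 (0.35 log units; beyond the scatter) close to the smaller of those two. Compound 4 is estimated at 70 nM with an expected range from 30 nM to 160 nM on this read-out.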

Compound 4, concentration for 50% growth inhibition: 56 nM
For compound 4 the middle estimate is 1.3-fold (0.10 log units) above the measured one, and the stated range covers the measured number.
By their numbers in this assay, from the lowest: compounds 3, 4, 1 and 2 (each within the scatter of the next, the first and the last beyond it).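

In this assay, the open methylamino group on the carbonyl carbon, which carries the amide hydrogen and no ring, holds up about as well as azetidin-1-yl (a 1.8-fold higher number from compound 3 to compound 4 (0.26 log units; within the scatter)). On the amide-type nitrogen, methyl separates from tert-butyl (a 2.2-fold lower number from compound 2 to compound 4 (0.33 log units; beyond the scatter)) but not from cyclopropyl (a 1.2-fold lower number from compound 1 to compound 4 (0.09 log units; within the scatter)), so only the tert-butyl amide stands apart from this methyl amide. No measurement offered here accounts for these numbers. As far as these compounds go, whether a primary amide, a pyrrolidin-1-yl amide or a morpholin-4-yl amide would fall within this range remains open.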